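From 4-methoxyphenyl to 4-bromophenyl

The compounds below may be only part of what the source reports. "The series", "measured", "known", "first", "only" and "open" are said of these compounds alone.

Within the data shown here, in a functional assay on A549 cells (Homo sapiens) for antiproliferative activity, read by MTT assay, with a stated time of 48 h (a higher number here means a weaker inhibitor, a lower number a stronger inhibitor), compound 1 (`COc1ccc(/C=C/C(=O)Nc2nnc(-c3ccc(C)cc3)s2)cc1`) gives 0.66 ug/mL and compound 2 (`COc1ccc(/C=C/C(=O)Nc2nnc(-c3ccc(OC)cc3)s2)cc1`) gives 0.52 ug/mL on the numbers so far. Among the measured compounds shown here, these two values stand within the scatter of each other, so compound 2 holds no real lead over the only other measured compound. The open case is compound 3 (`COc1ccc(/C=C/C(=O)Nc2nnc(-c3ccc(Br)cc3)s2)cc1`), which shares the core of compound 2 and carries bromo in place of methoxy on an aromatic carbon, para to a large group. The counted change is bromo in place of methoxy on an aromatic carbon and the same difference reads 4-methoxyphenyl to 4-bromophenyl.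

For the measured compounds named here, only one measured step bears on this: methoxy in place of methyl on an aromatic carbon, which gave a 1.3-fold lower number from compound 1 to compound 2 (0.10 log units; within the scatter) and nothing more. Going by the values given here, no bromo compound has been measured, so the data give no firm direction, and no step beyond the scatter is expected. The expected change is a 1.3-fold higher number from compound 2 to compound 3 (0.13 log units; within the scatter) and nothing larger. Compound 3 is estimated at 0.7 ug/mL in this assay with an expected range of 0.25 ug/mL to 2 ug/mL around that figure.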

Compound 3, half-maximal inhibitory concentration: 1.04 ug/mL
Compound 3: the middle estimate sits 1.5-fold (0.17 log units) below what was measured; measured number inside the range.
By their numbers in this assay, from the lowest: compounds 2, 1 and 3 (each within the scatter of the next).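

In this assay, bromo in place of methoxy gives a 2.0-fold higher number from compound 2 to compound 3 (0.30 log units; within the scatter) and bromo in place of methyl gives a 1.6-fold higher number from compound 1 to compound 3 (0.20 log units; within the scatter) and so neither step with bromo leaves the scatter. Where the earlier compounds covered only methyl and methoxy, this position, on an aromatic carbon and para to a large group, now also holds a halogen, with one heavy atom entering where methoxy had two, and the three compounds still cannot be told apart on these numbers. Nothing measured on this series speaks to why the readings stay so close.

Still open, from the compounds shown here alone, is whether this flat reading holds for groups of another kind at the same place, such as an amine, a carboxylic acid or a nitrile, and whether any group there can give a step beyond the scatter. All three compounds also share everything outside this one position, so how the series responds to a change elsewhere on the shared core remains unanswered as well.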